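From cyclobutyloxy to cyclopropyloxy on a shared core

The compounds below may be only part of what the source reports. "The series", "measured", "known", "first", "only" and "open" are said of these compounds alone.

In a functional assay on MCF7 cells (Homo sapiens) for antiproliferative activity, read by MTT assay, with a stated time of 48 h (on this read-out higher numbers stand for weaker inhibition and lower numbers for stronger inhibition), compound 1 `CCOc1cc(-c2ccc3[nH]ccc3c2)cn2c(-c3cc(OC)c(OC)c(OC)c3)nnc12` gives 284 nM, compound 2 `COc1cc(-c2nnc3c(OC4COC4)cc(-c4ccc5[nH]ccc5c4)cn23)cc(OC)c1OC` gives 2470 nM and compound 3 `COc1cc(-c2nnc3c(OC4CCC4)cc(-c4ccc5[nH]ccc5c4)cn23)cc(OC)c1OC` gives 267 nM. Compound 3 sits level with compound 1 at the low end of these numbers, and the gap up to the remaining value is a 9.3-fold lower number from compound 2 to compound 3 (0.97 log units; beyond the scatter). Compound 4 `COc1cc(-c2nnc3c(OC4CC4)cc(-c4ccc5[nH]ccc5c4)cn23)cc(OC)c1OC` carries cyclopropyl in place of cyclobutyl on an oxygen on an aromatic ring. Among the measured compounds shown here, two steps bear on this change. Cyclobutyl in place of ethyl gave a 1.1-fold lower number from compound 1 to compound 3 (0.03 log units; within the scatter), whereas oxetan-3-yl in place of ethyl gave an 8.7-fold higher number from compound 1 to compound 2 (0.94 log units; beyond the scatter). Cyclopropyl is again a ring of carbon only, so no step beyond the scatter is expected, and the estimated step is a 1.1-fold higher number from compound 3 to compound 4 (0.05 log units; within the scatter). The estimate for compound 4 is 300 nM, with an expected range of 120 nM to 750 nM.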

Compound 4, half-maximal inhibitory concentration: 259 nM
The estimate for compound 4 lay 1.2-fold (0.06 log units) above the measured number; measured number inside the range.
By their numbers in this assay, from the lowest: compounds 4, 3 and 1 (each within the scatter of the next); then compound 2.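

In this assay, a third carbon-only group on this oxygen falls in line with the other two: the step is a 1.0-fold lower number from compound 3 to compound 4 (0.01 log units; within the scatter), and the step from the ethyl compound is a 1.1-fold lower number from compound 1 to compound 4 (0.04 log units; within the scatter). Ring size, from cyclobutyl to cyclopropyl, therefore makes no readable difference here. Oxetan-3-yl remains the one group that goes against this pattern, with a 9.5-fold lower number from compound 2 to compound 4 (0.98 log units; beyond the scatter).

On these data alone, whether a larger ring such as cyclohexyl, or a chain carrying an amine, would fit the same pattern stays open. Nothing available explains the gap between oxetan-3-yl and the carbon-only groups.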